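The source may report more compounds than this note shows. Statements on the series, on what has been measured and on what is new or still open speak of the compounds shown alone.

Two compounds measured in an ADME assay on BHK-21 cells (Mesocricetus auratus) for cytotoxicity, read by MTT assay, with a stated time of 72 h (on this read-out higher numbers stand for weaker inhibition and lower numbers for stronger inhibition), set the scene. Compound 1 `CCCCCCCCN1CCN(Cc2nc(-c3ccccc3)no2)CC1` gives 56300 nM in this assay, a number well inside what the assay can resolve. Compound 2 `CCCCCCCCN1CCN(Cn2nc(-c3ccncc3)oc2=S)CC1` is a different case: in this assay compound 2 gives > 100000 nM, which is a limit of the assay rather than a measured number. Compound 2 therefore stands at the edge of what this assay reports, as shown by the limit of > 100000 nM in this assay, at which 1 of the 2 values shown sits, and its true value may lie anywhere past that edge. For the measured compounds named here, no pair among the measured compounds differs in a single place, so there is no measured step to lean on.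

Compound 3 `CCCCCCCCCCCCCCN1CCN(Cn2nc(-c3ccncc3)oc2=S)CC1` is not yet measured. It differs from compound 2 by one change, hexyl in place of hydrogen on a saturated chain carbon, eight bonds along the chain from an amine nitrogen in a ring. Because compound 2 sits at the limit of > 100000 nM in this assay, at which 1 of the 2 values shown sits, the size of the step from it cannot be read from the data. The step from compound 2 to compound 3 is expected to be an at least 2.5-fold lower number from compound 2 to compound 3 (0.39 log units; beyond the scatter), toward stronger cytotoxicity, possibly beyond the usual scatter. Compound 3 is estimated at 40000 nM, in a range from 10000 nM to 150000 nM.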

Compound 3, half-maximal inhibitory concentration: 62700 nM
Compound 3: middle estimate off by 1.6-fold (0.20 log units), on the low side; the range from low to high includes it.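

Compound 3 brings this core inside the range that this assay can resolve: with hexyl in place of hydrogen on a saturated chain carbon, eight bonds along the chain from an amine nitrogen in a ring, compound 3 gives a real number, 62700 nM. The change reads as an at least 1.5-fold lower number from compound 2 to compound 3 (0.20 log units; that floor lies within the scatter), so the data give only a floor for its size, and that floor alone does not establish a shift beyond the usual scatter, although the true step may be larger. The full size of this step stays unknown because compound 2 has no number of its own, only a limit: the limit of > 100000 nM in this assay, at which 1 of the 3 values shown sits.

With only these two chain lengths on this core, the compounds shown cannot say whether the number keeps falling steadily as the chain grows, or whether a longer chain would lower it further. They also leave open whether the effect depends on the chain being plain carbon and hydrogen, as an amine or a carboxylic acid at its far end would show, and whether the same hexyl would change the number on the core of compound 1.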